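Swapping the five-membered ring on the pendant aryl group

The source may report more compounds than this note shows. Statements on the series, on what has been measured and on what is new or still open speak of the compounds shown alone.

Measured compounds:
- Compound 1 `Cn1cc(-c2ccc(Cc3cc(C(=O)NC4CCOCC4)nc4c3ccn4C)cn2)cn1`: 0.08
- Compound 2 `Cn1ccc(-c2ccc(Cc3cc(C(=O)N[C@@H]4CCOC[C@H]4O)nc4c3ccn4C)cc2)n1`: 0.01

In an ADME assay on brain (Rattus norvegicus) for protein binding (on this read-out higher numbers stand for a larger free fraction and lower numbers for a smaller free fraction), compound 2 gives 0.01, the lowest of the two numbers recorded. Its nearest neighbour is compound 1, whose value of 0.08 lies beyond the usual scatter of the measurement, so the two compounds are clearly separated on this read-out.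

Compound 3 `Cn1ccc2c(Cc3ccc(-c4nccs4)cc3)cc(C(=O)N[C@@H]3CCOC[C@H]3O)nc21` has not yet been measured in this assay. It keeps the shared core and the hydroxylated oxane amide of compound 2, and differs only at the pendant six-membered aromatic ring of carbon only, where (1,3-thiazol-2-yl in place of 1-methyl-1H-pyrazol-3-yl on an aromatic carbon).

Within the data shown here, no pair of measured compounds that differ in one place is available, so the step cannot be anchored to a precedent. Compound 3 is expected to stay close to compound 2, with the step of a 1.3-fold lower number from compound 2 to compound 3 (0.10 log units; within the scatter) estimated to lie within the scatter, and its unbound fraction in this assay estimated at 0.008, with a range of 0.004 to 0.02.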

Compound 3, unbound fraction: 0.01
Compound 3: the middle estimate sits 1.3-fold (0.10 log units) below what was measured; the measured number falls inside the stated range.
By their numbers in this assay, from the lowest: compounds 2 and 3 (each within the scatter of the next); then compound 1.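

In this assay, putting 1,3-thiazol-2-yl in place of 1-methyl-1H-pyrazol-3-yl, on an aromatic carbon para to a large group, gives no change at the digits printed from compound 2 to compound 3 (within the scatter). Among these compounds, this is the first step that changes only one place, and it shows that at this position one five-membered aromatic ring with 2 hetero atoms can stand in for the other without a readable shift in the unbound fraction. Nothing shown accounts for this result.

On these data alone, it remains open whether a group of another kind at this position, such as a carboxylic acid or a dimethylamino group, would move the read-out away from these low values. Compound 1 differs from compound 2 in more than one place, so the gap between them cannot be assigned to the pendant ring, the hydroxyl on the oxane amide or any other single change.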